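Swapping Methylsulfanyl for a Benzyl Selenium Group

This account rests on a few compounds, and the source may have more. Where it says the series, first, only, none or still open, it means among the compounds named here.

Compound 1 `CS/C(=N\C(=O)c1csc([N+](=O)[O-])c1)NC(=O)c1csc([N+](=O)[O-])c1` gives > 100000 nM in a functional assay on HepG2 cells (Homo sapiens) for cytotoxicity, read by MTT assay, with a stated time of 72 h (a lower number here means that less compound is tolerated, a higher number that more compound is tolerated), which is a limit of the assay.
Compound 2 `O=C(/N=C(/NC(=O)c1ccno1)[Se]Cc1ccccc1)c1ccno1` gives > 100000 nM in this assay, also a limit.
Compound 3 `O=C(/N=C(/NC(=O)c1cccs1)[Se]Cc1ccccc1)c1cccs1` gives 81500 nM in this assay.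

Compound 1 stands at the limit of > 100000 nM in this assay, at which 2 of the 3 values shown sit, so only a bound is known for it, and compound 3 alone supplies a number. Compound 4 `O=C(/N=C(/NC(=O)c1csc([N+](=O)[O-])c1)[Se]Cc1ccccc1)c1csc([N+](=O)[O-])c1` differs from compound 1 by a group of 8 heavy atoms (7 carbon, 1 selenium; one six-membered aromatic ring of carbon only) in place of a group of 2 heavy atoms (1 carbon, 1 sulfur; no ring), on a carbon with a double bond to nitrogen. Within the data shown here, no measured pair isolates this change, so the step expected in this assay, an at least 1.1-fold lower number from compound 1 to compound 4 (0.04 log units; that floor lies within the scatter), is judged small and within the usual scatter. Compound 4 is therefore expected to give about 90000 nM in this assay, with a range from 30000 nM to 200000 nM.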

Compound 4, concentration lethal to 50% of the cells: 91600 nM
For compound 4 the middle estimate is 1.0-fold (0.01 log units) below the measured one; the measured number falls inside the stated range.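

Compound 1 gives > 100000 nM in this assay, which is a limit of the assay. Compound 4 turns that bound into a number for this series, and the change on the carbon with a double bond to nitrogen reads as an at least 1.0-fold lower number from compound 1 to compound 4 (0.03 log units; that floor lies within the scatter). That step is only a floor, and its true size stays unknown because compound 1 sits at a limit: the limit of > 100000 nM in this assay, at which 2 of the 4 values shown sit.

The compounds shown do not separate the selenium from the benzyl ring, which a benzylsulfanyl group in this place would do. On these data alone, whether an amine or a longer chain there would shift the number also remains open.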